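Series notes: methoxy in place of methyl at compound 3

The source may report more compounds than this note shows. Statements on the series, on what has been measured and on what is new or still open speak of the compounds shown alone.

Compound 1 `Cc1cccc(C)c1NC(=O)Nc1ccncc1` and compound 2 `Cc1cc(C)c(NC(=O)Nc2ccncc2)c(C)c1` were both run in a functional assay on the whole organism with Mus musculus as the target, in the maximal electroshock model, with a stated time of 30 min; on this read-out higher numbers stand for an effect only at larger amounts of compound and lower numbers for an effect already at smaller amounts. Compound 1 gives 30 mg/kg. Compound 2 gives 30 mg/kg, and the step of no change at the digits printed from compound 1 to compound 2 (within the scatter) leaves the two level at the digits shown, so no order between them can be read.

Compound 3 `COc1cc(C)c(NC(=O)Nc2ccncc2)c(C)c1` has not been measured. It differs from compound 2 by methoxy in place of methyl on an aromatic carbon.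

Among the measured compounds shown here, no measured step swaps methoxy for methyl, so nothing bears on this change directly. For the measured compounds named here, the only step in hand, no change at the digits printed from compound 1 to compound 2 (within the scatter), concerns a different substitution on the same ring and was flat. With no shift seen so far in either direction, the expected step of no change at the digits printed from compound 2 to compound 3 (within the scatter) is none beyond the scatter. Compound 3 is therefore estimated at 30 mg/kg, with an expected range from 15 mg/kg to 60 mg/kg.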

Compound 3, minimum effective dose: > 300 mg/kg
Compound 3: only a limit was reported; the forecaster's own chance of this, stated with the estimate: 10%; middle value at least 10-fold (1.00 log units) away from the limit.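

In this assay, the place para to a large group turns out not to be indifferent to its substituent: methoxy in place of methyl gives an at least 10-fold higher number from compound 2 to compound 3 (1.00 log units; beyond the scatter), whereas methyl in place of hydrogen gave no change at the digits printed from compound 1 to compound 2 (within the scatter). Methoxy in place of hydrogen gives the same picture, an at least 10-fold higher number from compound 1 to compound 3 (1.00 log units; beyond the scatter), so here the shift goes with methoxy and not with filling the place as such. For compound 3 the reading is a limit of the assay and not a number, so both of these steps give only a minimum size: the limit of > 300 mg/kg in this assay, at which 1 of the 3 values shown sits.

On these data alone, how far compound 3 lies past its limit stays open. Also open, as far as these compounds go, is whether the shift follows the oxygen or the extra heavy atom, a question that ethyl, hydroxyl or chlorine at this place would address.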